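The source may report more compounds than this note shows. Statements on the series, on what has been measured and on what is new or still open speak of the compounds shown alone.

Of the compounds shown here, two from the same series have been tested in a functional assay on MCF7 cells (Homo sapiens) for cytotoxicity, read by MTT assay, with a stated time of 72 h; a lower number here means a stronger inhibitor, a higher number a weaker inhibitor. Compound 1 `COc1ccccc1/C=C1\CCC/C(=C\c2cccc(OC)c2OC)C1=O` gives 12000 nM in this assay. Compound 2 `COc1ccc(/C=C2\CCC/C(=C\c3cccc(OC)c3OC)C2=O)cc1` gives 18600 nM in this assay. Among the measured compounds shown here, compound 2 stands alongside compound 1 rather than apart from it: the one measured step, a 1.6-fold higher number from compound 1 to compound 2 (0.19 log units; within the scatter), cannot be told apart from repeat measurements, so the two numbers are treated as equivalent.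

Compound 3 `COc1cc(/C=C2\CCC/C(=C\c3cccc(OC)c3OC)C2=O)ccc1O` is not yet measured. Its difference from compound 2 is 4-hydroxy-3-methoxyphenyl in place of 4-methoxyphenyl on a double-bonded chain carbon bound to a double-bonded ring carbon. For the measured compounds named here, no measured step touches a 4-hydroxy-3-methoxyphenyl group, so the only guidance is that the single known change at this position, a 1.6-fold higher number from compound 1 to compound 2 (0.19 log units; within the scatter), left the number essentially where it was. On that basis compound 3 is expected to show no step beyond the scatter, with a 1.2-fold lower number from compound 2 to compound 3 (0.09 log units; within the scatter) as the expected change. Compound 3 is therefore estimated at 15000 nM, within a range of 5000 nM to 45000 nM.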

Compound 3, half-maximal inhibitory concentration: 11600 nM
Compound 3: the middle estimate sits 1.3-fold (0.11 log units) above what was measured, and the stated range covers the measured number.
By their numbers in this assay, from the lowest: compounds 3, 1 and 2 (each within the scatter of the next).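

With the 4-hydroxy-3-methoxyphenyl group on the double-bonded chain carbon bound to a double-bonded ring carbon, this assay shows a 1.6-fold lower number from compound 2 to compound 3 (0.21 log units; within the scatter), and against the 2-methoxyphenyl group it shows a 1.0-fold lower number from compound 1 to compound 3 (0.01 log units; within the scatter). A group with a hydrogen-bond donor, which neither earlier group has, therefore leaves the number within the scatter, and the three groups tried at this place cannot be told apart. Nothing available here bears on why this change leaves the number where it was.

The compounds shown contain no step beyond the scatter, so they do not show which changes at this place, if any, matter in this assay. Going by these compounds, whether an amine, a carboxylic acid or a longer chain on the phenyl ring would move the number remains open.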